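A few compounds are considered here, and "the series" means these few. Any claim that something is new, unique, unknown or untested is made for them only; others in the source may bear on it.

Working notes, cytotoxicity series. All compounds are tested in a toxicity assay on NIH3T3 cells (Mus musculus) for cytotoxicity, read by resazurin assay; a higher number here means that more compound is needed for the effect, a lower number that less compound is needed. Compound 1 `COC(=O)c1ccc(NCc2cncn2Cc2ccccc2)cc1-c1ccccc1` gives > 1000 nM, which is a limit of the assay and not a number. Compound 2 `COC(=O)c1ccc(NCc2cncn2Cc2ccccc2C)cc1-c1ccccc1` gives 10000 nM. Compound 3 `Cc1cccc(-c2cccc(NCc3cncn3Cc3ccccc3)c2)c1` gives > 1000 nM, again a limit. The step that the limit leaves unreadable from compound 2 to compound 1 is the change (hydrogen in place of methyl on an aromatic carbon); its size cannot be read because of the limit of > 1000 nM in this assay, at which 2 of the 3 values shown sit. How the core of compound 3 differs from that of compound 2 is not broken down here. Compound 4 `c1ccc(Cn2cncc2CNc2cccc(-c3ccccc3)c2)cc1` is not yet measured; it differs from compound 3 by hydrogen in place of methyl on an aromatic carbon, the same kind of change as before, though the place is meta to a large group rather than ortho to a large group. The step that the limit leaves unreadable from compound 3 to compound 4 is expected to be small. This rests on compound 1, which after the same change sits at > 1000 nM. Compound 4 is estimated at 5000 nM, between 1000 nM and 30000 nM.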

Compound 4, half-maximal effective concentration: > 750 nM
Compound 4 ended at the assay's limit; the forecaster's own chance of this, stated with the estimate: 60%; the middle value lies beyond the limit too.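

The steps from compound 3 to compound 4 and from compound 1 to compound 4 cannot be read, as all three compounds stand at assay limits. The compounds shown leave open what size of step hydrogen in place of methyl on an aromatic carbon gives.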